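Solubility notes: fluoro to methyl on the aryl ring

A few compounds are considered here, and "the series" means these few. Any claim that something is new, unique, unknown or untested is made for them only; others in the source may bear on it.

Measured so far:
Compound 1 `Cc1cc(NCc2ccccn2)n2ncc(-c3ccc(F)cc3)c2n1` gives < 5000 nM in a physicochemical assay for solubility, read by HPLC, using the shake flask method, measured as kinetic solubility, with a stated time of 2 h, at pH 7.4 (a higher number here means a more soluble compound, a lower number a less soluble compound), a limit of the assay rather than a number.
Compound 2 `Cc1cc(NCc2ccccn2)n2ncc(-c3cccc(F)c3)c2n1` gives 5000 nM in this assay.
Compound 3 `Cc1cc(NCc2ccccn2)n2ncc(-c3ccccc3F)c2n1` gives 5000 nM in this assay.

Compound 3 stands level with compound 2 at the digits shown; the step of no change at the digits printed from compound 2 to compound 3 (within the scatter) lies within the scatter. Against compound 1 the steps of a number no lower from compound 1 to compound 2 (the limit leaves the size open) and a number no lower from compound 1 to compound 3 (the limit leaves the size open) are open in size, since the value of compound 1 is the limit noted in the limit of < 5000 nM in this assay, at which 1 of the 3 values shown sits. Within the three measured compounds the three fluorophenyl positions therefore give no readable spread in this assay.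

Compound 4 `Cc1cc(NCc2ccccn2)n2ncc(-c3ccccc3C)c2n1` differs from compound 3 by methyl in place of fluoro on an aromatic carbon. Within the data shown here, no measured step exchanges fluoro for methyl; the measured steps only move fluoro around the phenyl ring, and the one readable step among them, no change at the digits printed from compound 2 to compound 3 (within the scatter), is within the scatter. The expectation for the step of no change at the digits printed from compound 3 to compound 4 (within the scatter) is therefore no change beyond the scatter, with some chance that the assay again reports only a limit. Compound 4 is estimated at 5000 nM, expected to fall between 2000 nM and 12000 nM.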

Compound 4, solubility: < 5000 nM
Compound 4: only a limit was reported (the forecaster's own chance of this, stated with the estimate: 40%); the middle value lies on the limit itself.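

In this assay compound 4 gives < 5000 nM, a limit of the assay and not a number. Among these compounds, the 2-methylphenyl group is the first group other than a fluorophenyl at this place in the measured set, and its steps are bounded in one direction only: a number no higher from compound 3 to compound 4 (the limit leaves the size open), and a number no higher from compound 2 to compound 4 (the limit leaves the size open), while the step to compound 4 from the other compound held at a limit cannot be read. The exchange of fluoro for methyl, ortho to a large group, therefore gives no measured size, and the readings of the set now rest as much on the assay limit as on numbers: the limit of < 5000 nM in this assay, at which 2 of the 4 values shown sit.

On these data alone, how far compound 4 lies under its limit, and so whether methyl in place of fluoro moves the reading beyond the scatter, stays open. Also open, as far as these compounds go, is whether an amine or a carboxylic acid on the same aromatic carbon would bring a reading clear of the limit and give this position a step of readable size.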